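Chloro for Fluoro on a Bis-benzylidene Cyclohexanone Core

A few compounds are considered here, and "the series" means these few. Any claim that something is new, unique, unknown or untested is made for them only; others in the source may bear on it.

Measured compounds:
compound 1, `O=C1/C(=C/c2ccc(F)cc2)CCC/C1=C\c1cccc([N+](=O)[O-])c1`, 5.06
compound 2, `O=C1/C(=C/c2ccc(F)cc2)CCC/C1=C\c1ccccc1[N+](=O)[O-]`, 4.86
compound 3, `O=C1/C(=C/c2ccc(Cl)cc2)CCC/C1=C\c1ccccc1[N+](=O)[O-]`, 4.86

Of the compounds shown here, three have been measured in a physicochemical assay for lipophilicity (on this read-out lower numbers stand for lower lipophilicity and higher numbers for higher lipophilicity), and a fourth, compound 4, `O=C1/C(=C/c2ccc(Cl)cc2)CCC/C1=C\c1cccc([N+](=O)[O-])c1`, has not. Compound 1 and compound 2 share the same atoms joined differently; how the two cores differ is not broken down here. In this assay compound 1 gives 5.06, and compound 2 gives 4.86; the two values lie within the scatter of each other, so no order between them is claimed. Compound 3 gives 4.86.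

Between compound 2 and compound 3 the change is chloro in place of fluoro on an aromatic carbon, and the step it made is no change at the digits printed from compound 2 to compound 3 (within the scatter). The same change turns compound 1 into compound 4: chloro in place of fluoro on an aromatic carbon. Going by the values given here, the place of the change is worded the same for both pairs, so the two changes are the same and the measured pair is the only guide.

Because the step of no change at the digits printed from compound 2 to compound 3 (within the scatter) was within the scatter, the step from compound 1 to compound 4 is expected to be about as small, no change at the digits printed from compound 1 to compound 4 (within the scatter). On that basis compound 4 is estimated at 5.06 in this assay, with an expected range from 4.76 to 5.36. This rests on a single measured pair, compound 2 and compound 3, and on no more.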

Compound 4, partition coefficient: 5.06
Beside the measured number, compound 4's estimate shows no gap at the digits printed; the measured number falls inside the stated range.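

In this assay, chloro in place of fluoro on an aromatic carbon now reads the same way on two cores: no change at the digits printed from compound 1 to compound 4 (within the scatter), alongside no change at the digits printed from compound 2 to compound 3 (within the scatter). Within these four compounds, then, the change carried from the core of compound 2 to the core of compound 1 with neither step going beyond the scatter, and no compound here goes against that. This is a match across two pairs and no more, so it does not show that the change would stay this small on any further core or in any other read-out, and nothing at hand accounts for the two steps being alike.

What the compounds leave open is how a group other than chloro or fluoro, such as bromo, methyl, an amine or a carboxylic acid, would read in this assay at the same place, where 4-fluorophenyl gives way to 4-chlorophenyl. Also open, from the compounds shown here alone, is whether the chloro-for-fluoro step stays this small on a core that carries a longer chain or an amide.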